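Adding a methyl to a propoxy chain on a purine antagonist

This account rests on a few compounds, and the source may have more. Where it says the series, first, only, none or still open, it means among the compounds named here.

In a series of purine-type antagonists, compound 1 `O=CN(c1ncnc2c1ncn2CC1CC1)C1CC1` gives 30 mg/kg in a functional assay on the whole organism for antagonist activity, with Rattus norvegicus as the target; a higher number here means that more compound is needed for the effect, a lower number that less compound is needed. Compound 2 `CC(C1CC1)n1cnc2c(N(C=O)C3CC3)ncnc21` carries one change relative to compound 1, namely (methyl in place of hydrogen on a saturated chain carbon bound to an aromatic nitrogen and a saturated ring carbon), and in this assay compound 2 gives 7.5 mg/kg; the step of a 4.0-fold lower number from compound 1 to compound 2 (0.60 log units; beyond the scatter). Compound 3 `CCOc1nc(NC2CC2)c2ncn(CC3CC3)c2n1` is built on a different core, and how its core differs from that of compound 1 is not broken down here; in this assay compound 3 gives 4 mg/kg, a value that sits within the scatter of compound 2. Compound 4 `CCCOc1nc(NC2CC2)c2ncn(CC3CC3)c2n1` differs from compound 3 by methyl in place of hydrogen on a saturated chain carbon, two bonds along the chain from an oxygen on an aromatic ring. This is the same kind of change as that from compound 1 to compound 2, a methyl in place of hydrogen, but the place differs: in the earlier pair it sits on a saturated chain carbon bound to an aromatic nitrogen and a saturated ring carbon, here on a saturated chain carbon two bonds along the chain from an oxygen on an aromatic ring. Within the data shown here, since the one measured step of this kind, a 4.0-fold lower number from compound 1 to compound 2 (0.60 log units; beyond the scatter), is modest and sits at another place, the expected step is a small one, a 1.3-fold lower number from compound 3 to compound 4 (0.12 log units; within the scatter). Compound 4 is accordingly expected to give about 3 mg/kg in this assay, with a likely range from 1.2 mg/kg to 8 mg/kg.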

Compound 4, dose for half-maximal effect: 2.5 mg/kg
Compound 4: the middle estimate sits 1.2-fold (0.08 log units) above what was measured; measured number inside the range.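

In this assay the step from ethoxy to propoxy is a 1.6-fold lower number from compound 3 to compound 4 (0.20 log units; within the scatter), so the added methyl gives no difference that can be read on this core. Set beside the earlier methyl step, the two steps cannot be told apart: the same change on two cores in this assay, a 4.0-fold lower number (0.60 log units; beyond the scatter) from compound 1 to compound 2 and a 1.6-fold lower number (0.20 log units; within the scatter) from compound 3 to compound 4, 2.5-fold (0.40 log units) apart, within the scatter of two such steps. This shows that the two results are compatible, but with one pair on each core and the methyl at a different place in each pair, it does not show that the change carries from one core to another or that a step of a given size would recur in this series.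

The compounds shown leave open how a longer chain such as butoxy, or an amine in place of the propoxy chain, would read on the core of compound 3. They also leave open what the methyl on the saturated chain carbon bound to an aromatic nitrogen and a saturated ring carbon would give on that core.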